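Benzylamine ring substitution on the shared nucleoside core

This account rests on a few compounds, and the source may have more. Where it says the series, first, only, none or still open, it means among the compounds named here.

Measured compounds:
compound 1 `OC[C@H]1O[C@@H](n2cnc3c(NCc4ccccc4F)ncnc32)[C@H](O)[C@@H]1O`, > 166000 nM
compound 2 `OC[C@H]1O[C@@H](n2cnc3c(NCc4ccc(F)cc4)ncnc32)[C@H](O)[C@@H]1O`, 21000 nM
compound 3 `OC[C@H]1O[C@@H](n2cnc3c(NCc4cccc(Br)c4)ncnc32)[C@H](O)[C@@H]1O`, > 166000 nM

In a functional assay on MCF cells (Homo sapiens) for antiproliferative activity, with a stated time of 72 h (on this read-out higher numbers stand for weaker inhibition and lower numbers for stronger inhibition), compound 1 gives > 166000 nM, a limit of the assay and not a number. Compound 2 gives 21000 nM. Compound 3 stands at > 166000 nM, again a limit; it shares this with one other value, (the limit of > 166000 nM in this assay, at which 2 of the 3 values shown sit). The change to compound 4 `COc1ccc(CNc2ncnc3c2ncn3[C@@H]2O[C@H](CO)[C@@H](O)[C@H]2O)c(OC)c1` is 2,4-dimethoxyphenyl in place of 3-bromophenyl on a saturated chain carbon bound to a nitrogen on an aromatic ring. Relevant measured steps: an at least 7.9-fold lower number from compound 1 to compound 2 (0.89 log units; beyond the scatter), an at least 7.9-fold higher number from compound 2 to compound 3 (0.89 log units; beyond the scatter), a step that the two limits leave unreadable from compound 1 to compound 3. Among the compounds with values here, none of them introduces a methoxy group, so they show only that the ring substitution pattern shifts the number at least modestly. Compound 4 is therefore expected near 60000 nM, between 15000 nM and 200000 nM. The expected step is an at least 2.7-fold lower number from compound 3 to compound 4 (0.44 log units; beyond the scatter), with a further limit about as likely as a number.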

Compound 4, half-maximal inhibitory concentration: > 166000 nM
Compound 4: no number, only a limit (the forecaster's own chance of this, stated with the estimate: 50%); middle value at least 2.7-fold (0.44 log units) away from the limit.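

Within the data shown here, compound 4 brings methoxy groups into the series for the first time, and its value is again a limit and not a number. Among these compounds, the step to the only measured number is an at least 7.9-fold higher number from compound 2 to compound 4 (0.89 log units; beyond the scatter), so 4-fluorophenyl remains the only group at this place to give a number, and the steps from compound 1 and compound 3 to compound 4 cannot be read, since both ends are limits. The series now clusters at one limit: the limit of > 166000 nM in this assay, at which 3 of the 4 values shown sit.

As far as these compounds go, how the three groups at the limit rank stays open. Also open, from the compounds shown here alone, is whether a phenyl carrying a single methoxy group, an amine or a carboxylic acid at this place would give a number.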